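This account rests on a few compounds, and the source may have more. Where it says the series, first, only, none or still open, it means among the compounds named here.

Measured compounds in a physicochemical assay for lipophilicity; on this read-out higher numbers stand for higher lipophilicity and lower numbers for lower lipophilicity:
compound 1 `CC(/C=C/CC(C)CCCC(C)C)=C\C(=O)OCC(C)C`, 7.69
compound 2 `CCOC(=O)/C=C(C)/C=C/CC(C)CCC(OC)C(C)(C)OC`, 4.34
compound 3 `CC(/C=C/CC(C)CCCC(C)(C)C)=C\C(=O)OC(C)C`, 7.56

Three esters were measured in this assay. Compound 1 gives 7.69 and holds the highest of the three numbers. Compound 3 gives 7.56, a number that lies within the scatter of compound 1, so the two cannot be told apart on this read-out. Compound 2 gives 4.34, which lies far below compound 1, well beyond the scatter.

The unmeasured compound 4 `C=CCNC(=O)/C=C(C)/C=C/CC(C)CCCC(C)C` is reached from compound 1 by a single change: allylamino in place of isobutoxy on a carbonyl carbon. Among the measured compounds shown here, no pair of measured compounds shows this change, so no measured step for it exists here. In this assay the exchange of isobutoxycarbonyl for allylcarbamoyl is expected to lower the number by a clear margin, beyond the scatter, and the expected step is a number 1.59 log units lower from compound 1 to compound 4 (beyond the scatter). Compound 4 is accordingly estimated at 6.1, with a range from 5.4 to 6.8.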

Compound 4, partition coefficient: 5.23
Compound 4: middle estimate off by 0.87 log units, on the high side; the whole stated range lies above it.
By their numbers in this assay, from the lowest: compound 2; then compound 4; then compounds 3 and 1 (each within the scatter of the next).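

In this assay, among the compounds shown here, the exchange of isobutoxy for allylamino on a carbonyl carbon gives the first measured step at this position, and it is a large one: a number 2.46 log units lower from compound 1 to compound 4 (beyond the scatter). The earlier compounds shown here differ from one another in more than one place, so they gave no step for this position, and only now is it clear that the group on this carbonyl carbon can by itself move the read-out by a wide margin. Nothing available explains the size of this step.

The compounds shown leave open whether the step goes with the nitrogen link or with the allyl chain, which an isobutylamino or an allyloxy group on this carbonyl carbon would tell apart. On these data alone, how a carboxylic acid or a tertiary amide would read at this place also stays open.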